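Antiproliferative series: loss of the ring-nitrogen aryl group

The source may report more compounds than this note shows. Statements on the series, on what has been measured and on what is new or still open speak of the compounds shown alone.

Measured compounds:
Compound 1 `CC(=O)Oc1cccc(N2C(=O)/C(=C/N3N=C(c4ccccc4)CC3c3ccccc3O)SC2=S)c1`: 118 nM
Compound 2 `CC(=O)Oc1cccc(N2C(=O)/C(=C/N3N=C(c4ccccc4)CC3c3ccc(N(C)C)cc3)SC2=S)c1`: 100 nM

In a functional assay on HL-60 cells (Homo sapiens) for antiproliferative activity, read by MTT assay, with a stated time of 72 h (a higher number here means a weaker inhibitor, a lower number a stronger inhibitor), compound 2 gives 100 nM and compound 1 gives 118 nM. The step of a 1.2-fold lower number from compound 1 to compound 2 (0.07 log units; within the scatter) lies within the scatter, so compound 2 stands level with compound 1 rather than apart from it. Compound 3 `CN(C)c1ccc(C2CC(c3ccccc3)=NN2/C=C2\SC(=S)NC2=O)cc1` differs from compound 2 by hydrogen in place of 3-acetoxyphenyl on an amide-type nitrogen in a ring. For the measured compounds named here, no measured step concerns this position. Going by the values given here, the only step known concerns a different group and stayed within the scatter, so it gives no guide here. Removing a group of this size is expected to shift the number, most plausibly toward a weaker inhibitor, with wide uncertainty. Compound 3 is therefore estimated at 300 nM, with a range from 80 nM to 1500 nM, meaning a step of a 3.0-fold higher number from compound 2 to compound 3 (0.48 log units; beyond the scatter).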

Compound 3, half-maximal inhibitory concentration: > 10000 nM
Compound 3: a limit, no number; the forecaster's own chance of this, stated with the estimate: 10%; middle value at least 33-fold (1.52 log units) away from the limit.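

In this assay compound 3 gives > 10000 nM as a limit of the assay, not a number. Hydrogen in place of 3-acetoxyphenyl on the amide-type nitrogen gives an at least 100-fold higher number from compound 2 to compound 3 (2.00 log units; beyond the scatter) as the step, so this position carries far more of the activity than the saturated ring carbon varied earlier, where the step stayed within the scatter. The substituent on this nitrogen is therefore required for activity in this pair.

Still open, from the compounds shown here alone, is whether the aromatic ring or the acetoxy group matters: an unsubstituted phenyl, a 3-hydroxyphenyl or a simple methyl on this nitrogen would separate them.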